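Two small substituent changes in a cytotoxicity series

The compounds below may be only part of what the source reports. "The series", "measured", "known", "first", "only" and "open" are said of these compounds alone.

Measured so far:
- compound 1 `CC(=O)c1nn(-c2ccc(C)cc2)/c(=N/c2nc(-c3c(C)n(C)n(-c4ccccc4)c3=O)cs2)s1`: in a functional assay on A549 cells (Homo sapiens) for cytotoxicity, read by sulforhodamine B assay, with a stated time of 72 h (a higher number here means a weaker inhibitor, a lower number a stronger inhibitor), compound 1 gives 20700 nM
- compound 2 `COc1ccc(-n2nc(C(C)=O)s/c2=N\c2nc(-c3c(C)n(C)n(-c4ccccc4)c3=O)cs2)cc1`: compound 2 gives 26500 nM
- compound 3 `CCOC(=O)c1nn(-c2ccc(C)cc2)/c(=N/c2nc(-c3c(C)n(C)n(-c4ccccc4)c3=O)cs2)s1`: compound 3 gives only a limit of the assay, > 100000 nM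

Compound 2 differs from compound 1 by methoxy in place of methyl on an aromatic carbon, and that change made a 1.3-fold higher number from compound 1 to compound 2 (0.11 log units; within the scatter). Compound 3 differs from compound 1 by ethoxy in place of methyl on a carbonyl carbon, which made an at least 4.8-fold higher number from compound 1 to compound 3 (0.68 log units; beyond the scatter). Compound 4 `CCOC(=O)c1nn(-c2ccc(OC)cc2)/c(=N/c2nc(-c3c(C)n(C)n(-c4ccccc4)c3=O)cs2)s1` is not yet measured; it differs from compound 3 by methoxy in place of methyl on an aromatic carbon, the same change as that from compound 1 to compound 2. For the step from compound 3 to compound 4 the expectation is a step that the limit leaves unreadable from compound 3 to compound 4, resting on a 1.3-fold higher number from compound 1 to compound 2 (0.11 log units; within the scatter). Since compound 3 sits at the limit of > 100000 nM in this assay, at which 1 of the 3 values shown sits, a limit is again the likely outcome for compound 4. Compound 4 is therefore estimated at 150000 nM in this assay, expected between 60000 nM and 400000 nM.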

Compound 4, half-maximal inhibitory concentration: 13100 nM
The estimate for compound 4 lay 11-fold (1.06 log units) above the measured number; measured number below the stated range.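

In this assay, methoxy in place of methyl on the aromatic carbon gave an at least 7.6-fold lower number from compound 3 to compound 4 (0.88 log units; beyond the scatter), which does not match the earlier step for this change: the same change on two cores in this assay, a 1.3-fold higher number (0.11 log units; within the scatter) from compound 1 to compound 2 and an at least 7.6-fold lower number (0.88 log units; beyond the scatter) from compound 3 to compound 4, at least 9.7-fold (0.99 log units) apart, beyond the scatter of two such steps

Ethoxy in place of methyl on the carbonyl carbon gave a 2.0-fold lower number from compound 2 to compound 4 (0.31 log units; beyond the scatter), opposite in direction to the earlier step for this change: the same change on two cores in this assay, an at least 4.8-fold higher number (0.68 log units; beyond the scatter) from compound 1 to compound 3 and a 2.0-fold lower number (0.31 log units; beyond the scatter) from compound 2 to compound 4, at least 9.7-fold (0.99 log units) apart, beyond the scatter of two such steps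

Compound 3 gives > 100000 nM, a limit of the assay and not a number, so these results show that neither change carried unchanged from one core to the other, but they do not fix the full size of the gaps or show why they arise.

From the compounds shown here alone, it remains open how an amine or a chlorine in place of the methoxy would behave on either core. Going by these compounds, the effect of a longer chain in place of the ethoxy is also open.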